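Aryl cap replacement with hydroxyindole in a hydroxamate series

The source may hold more compounds than are shown below. What is called first, only, known or untested is meant among the compounds shown, and "the series" means these compounds.

Measured so far:
- compound 1, `CN(C)c1ccc(C(=O)N[C@@H](CCCCCC(=O)NO)C(=O)NCc2ccccc2)cc1`: 12000 nM
- compound 2, `O=C(CCCCC[C@H](NC(=O)c1ccc(C(F)(F)F)cc1)C(=O)NCc1ccccc1)NO`: 1610 nM

In a functional assay on NFF cells (Homo sapiens) for antiproliferative activity (on this read-out lower numbers stand for stronger inhibition and higher numbers for weaker inhibition), compound 2 gives the lowest of the two numbers; compound 1 gives 12000 nM, and the step of a 7.5-fold lower number from compound 1 to compound 2 (0.87 log units; beyond the scatter) is beyond the scatter. Compound 3, `O=C(CCCCC[C@H](NC(=O)c1cc2c(O)cccc2[nH]1)C(=O)NCc1ccccc1)NO`, has not been measured. It differs from compound 2 by 4-hydroxy-1H-indol-2-yl in place of 4-(trifluoromethyl)phenyl on a carbonyl carbon. Among the compounds with values here, the one measured step, a 7.5-fold lower number from compound 1 to compound 2 (0.87 log units; beyond the scatter), changes a substituent on the same aromatic cap while keeping the ring; it does not cover exchange of the whole cap for a bicyclic one, so it bears only loosely on this step. On that thin basis no step beyond the scatter is firmly expected in either direction, and a number near that of compound 2 is the working assumption, with a wide range. Compound 3 is therefore estimated at 1200 nM, between 300 nM and 5000 nM. The corresponding step is expected to be a 1.3-fold lower number from compound 2 to compound 3 (0.13 log units; within the scatter).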

Compound 3, half-maximal inhibitory concentration: 2210 nM
Compound 3: the middle estimate sits 1.8-fold (0.27 log units) below what was measured, and the stated range covers the measured number.
By their numbers in this assay, from the lowest: compounds 2 and 3 (each within the scatter of the next); then compound 1.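

Exchanging the whole cap on the carbonyl carbon, from 4-(trifluoromethyl)phenyl to the two-ring 4-hydroxy-1H-indol-2-yl, gives in this assay the step of a 1.4-fold higher number from compound 2 to compound 3 (0.14 log units; within the scatter), so at this position a single carbon-only ring and a two-ring cap carrying hydrogen-bond donors read alike. The step of a 5.4-fold lower number from compound 1 to compound 3 (0.73 log units; beyond the scatter), read with the one from compound 1 to compound 2, leaves the 4-(dimethylamino)phenyl cap of compound 1 alone at the high end among these three, with two quite different caps together at the low end. Nothing on hand explains why these caps read as they do.

The compounds shown leave open what the hydroxyl of the indole contributes, as a methoxy group there or an unsubstituted indole would test. They also leave open how a carboxylic acid or a primary amine on the cap would read, and whether a longer chain would shift any of these numbers.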